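Cyclobutylmethyl replaces cyclohexyl on the ring amide nitrogen

The source may report more compounds than this note shows. Statements on the series, on what has been measured and on what is new or still open speak of the compounds shown alone.

Three compounds on a shared core were tested in an ADME assay on Huh-7 cells (Homo sapiens) for cytotoxicity, with a stated time of 72 h; a lower number here means that less compound is tolerated, a higher number that more compound is tolerated. Compound 1 `CS(=O)(=O)Nc1ccc2c(c1)S(=O)(=O)N=C(C1=C(O)C3CCCC3N(CCC3CC3)C1=O)N2` gives only a limit of the assay, > 33000 nM. Compound 2 `CS(=O)(=O)Nc1ccc2c(c1)S(=O)(=O)N=C(C1=C(O)C3CCCC3N(Cc3ccc(F)cn3)C1=O)N2` likewise gives only a limit, > 33000 nM. Compound 3 `CS(=O)(=O)Nc1ccc2c(c1)S(=O)(=O)N=C(C1=C(O)C3CCCC3N(C3CCCCC3)C1=O)N2` reaches only a limit as well, > 10000 nM. On the numbers shown, compound 3 stands at the limit of > 10000 nM in this assay, at which 1 of the 3 values shown sits. The other two compounds sit at the limit of > 33000 nM in this assay, at which 2 of the 3 values shown sit. None of the three values is a number. Among the measured compounds shown here, the steps among them are a step that the two limits leave unreadable from compound 1 to compound 2, a step that the two limits leave unreadable from compound 1 to compound 3 and a step that the two limits leave unreadable from compound 2 to compound 3, so no step in this assay has a readable size. Compound 4 `CS(=O)(=O)Nc1ccc2c(c1)S(=O)(=O)N=C(C1=C(O)C3CCCC3N(CC3CCC3)C1=O)N2` differs from compound 3 by cyclobutylmethyl in place of cyclohexyl on an amide-type nitrogen in a ring. For the measured compounds named here, no measured step resolves a change of this kind: every value is a limit, and all three limits show that the compounds are tolerated across the range examined. The expectation is that compound 4 will again reach only a limit in this assay, with an estimated value of 40000 nM (range 12000 nM to 120000 nM). The expected step is a step that the limit leaves unreadable from compound 3 to compound 4, nothing beyond the scatter.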

Compound 4, half-maximal cytotoxic concentration: > 33000 nM
Compound 4: no number, only a limit (the forecaster's own chance of this, stated with the estimate: 85%); the middle value does not contradict the limit.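

Compound 4, like compound 1, compound 2 and compound 3, gives only a limit in this assay, so none of the steps from compound 1, compound 2 or compound 3 to compound 4 can be read. The compounds shown leave open whether any group on the amide-type nitrogen in a ring changes the half-maximal cytotoxic concentration.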